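The compounds below may be only part of what the source reports. "The series", "measured", "known", "first", "only" and "open" are said of these compounds alone.

Among the compounds with values here, compound 2 `COc1cc(-c2cc(/C=C/C(=O)c3ccc(N)cc3)[nH]n2)cc(OC)c1OC` stands at the high end of the three numbers so far: in a functional assay on NCI-H522 cells (Homo sapiens) for inhibition, read by sulforhodamine B assay, with a stated time of 48 h (a lower number here means a stronger inhibitor of growth, a higher number a weaker inhibitor of growth), compound 2 gives 3990 nM. Compound 1 `COc1ccc(-c2cc(/C=C/C(=O)c3ccc(N)cc3)[nH]n2)cc1` gives 2910 nM, within the scatter of compound 2. Within the data shown here, compound 3 `COc1ccc(C(=O)/C=C/c2cc(-c3cc(OC)c(OC)c(OC)c3)n[nH]2)cc1OC` gives 390 nM; the only measured single-place step, a 10-fold lower number from compound 2 to compound 3 (1.01 log units; beyond the scatter), alters the group on the carbonyl carbon, not the six-membered aromatic ring changed here. Compound 4 `COc1ccc(-c2cc(/C=C/C(=O)c3ccc(N)cc3)[nH]n2)cc1OC` differs from compound 2 by hydrogen in place of methoxy on an aromatic carbon. Among the measured compounds shown here, no measured step tests that ring directly, and compounds 1 and 2, which differ in how many methoxy groups sit on it, lie within scatter of each other, so no step beyond the scatter is expected. Compound 4 is therefore estimated at 3400 nM (range 1500 nM to 7500 nM). The expected step is a 1.2-fold lower number from compound 2 to compound 4 (0.07 log units; within the scatter).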

Compound 4, concentration for total growth inhibition: 3220 nM
Compound 4: middle estimate off by 1.1-fold (0.02 log units), on the high side; the range from low to high includes it.
By their numbers in this assay, from the lowest: compound 3; then compounds 1, 4 and 2 (each within the scatter of the next).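

Compound 4 gives the first direct test of this place on the ring. Hydrogen in place of methoxy gives a 1.2-fold lower number from compound 2 to compound 4 (0.09 log units; within the scatter) and methoxy in place of hydrogen gives a 1.1-fold higher number from compound 1 to compound 4 (0.04 log units; within the scatter), so with 4-aminophenyl on the carbonyl carbon, neither swap moves the number beyond the scatter. Still open, from the compounds shown here alone, is whether a hydroxyl group or a chlorine atom here would also stay within the scatter, and whether the same holds with the 3,4-dimethoxyphenyl group of compound 3 on the carbonyl carbon. No other measurement bears on this result.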